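The compounds below may be only part of what the source reports. "The series", "measured", "known", "first", "only" and "open" are said of these compounds alone.

Measured compounds in a functional assay on HeLa cells (Homo sapiens) for cytotoxicity, read by MTT assay, with a stated time of 72 h; a higher number here means a weaker inhibitor, a lower number a stronger inhibitor:

Compound 1, `Cc1nnc(SCc2cc(=O)c3cc(Cl)ccc3o2)o1`: > 25000 nM, which is a limit of the assay rather than a number.
Compound 2, `Cc1nnc(SCc2cc(=O)c3ccccc3o2)o1`: > 25000 nM, again a limit of the assay.
Compound 3, `Nc1nnc(SCc2cc(=O)c3ccccc3o2)s1`: > 25000 nM, once more a limit of the assay.

Compound 3 therefore stands at the limit of this assay, and the two other values shown sit at the same limit, as summarised by the limit of > 25000 nM in this assay, at which 3 of the 3 values shown sit. For the measured compounds named here, no compound in this set has yet returned a number.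

Compound 4, `Nc1nnc(SCc2cc(=O)c3cc(Cl)ccc3o2)s1`, is compound 3 with chloro in place of hydrogen on an aromatic carbon; the chloro enters on an aromatic carbon of a six-membered aromatic ring of carbon only, part of a fused system of two rings, meta to a fused ring and para to a fused ring. Going by the values given here, the one measured step that involves the same exchange, in the opposite direction, is a step that the two limits leave unreadable from compound 1 to compound 2, and the only other measured step, a step that the two limits leave unreadable from compound 2 to compound 3, is likewise unreadable. Among the compounds with values here, nothing measured so far gives a size or a direction for the step to compound 4.

On that basis compound 4 is expected to sit at the limit as well, with an estimate of 30000 nM and a range from 10000 nM to 100000 nM. The step this estimate implies is a step that the limit leaves unreadable from compound 3 to compound 4, which is expected to be none beyond the scatter.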

Compound 4, half-maximal inhibitory concentration: > 25000 nM
Compound 4: no number, only a limit (the forecaster's own chance of this, stated with the estimate: 85%); the middle value does not contradict the limit.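

No new step can be read in this assay: the pairs compound 3 with compound 4 and compound 1 with compound 4 each join two limits of the assay, not numbers: the limit of > 25000 nM in this assay, at which 4 of the 4 values shown sit.

The compounds shown leave open whether chloro in place of hydrogen, or 5-amino-1,3,4-thiadiazol-2-yl in place of 5-methyl-1,3,4-oxadiazol-2-yl, makes any difference in this assay.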